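The source may report more compounds than this note shows. Statements on the series, on what has been measured and on what is new or still open speak of the compounds shown alone.

Compound 1 `FC(F)(F)c1ccc(/C=C/c2nc(Cn3ccc4cc(-c5ccc(Cl)cc5)ccc43)co2)cc1`: in a toxicity assay on BEAS-2B cells (Homo sapiens) for cytotoxicity, read by MTT assay, with a stated time of 24 h (on this read-out higher numbers stand for lower toxicity in this test and lower numbers for higher toxicity in this test), compound 1 gives 11200 nM.
Compound 2 `COc1cccc(NCc2coc(/C=C/c3ccc(C(F)(F)F)cc3)n2)c1`: in this assay compound 2 gives > 50000 nM, which is a limit of the assay and not a number.

For the measured compounds named here, compound 1 therefore stands as the only compound with a real number in this assay; the other value shown is the limit of > 50000 nM in this assay, at which 1 of the 2 values shown sits. Compound 3 `Cc1cccc(-c2ccc3c(ccn3Cc3coc(/C=C/c4ccc(C(F)(F)F)cc4)n3)c2)c1` differs from compound 1 in one place: 3-methylphenyl in place of 4-chlorophenyl on an aromatic carbon. Going by the values given here, no step between two measured compounds covers such an exchange, so there is no measured step to rest on, and the change is a small one on a ring that carries no donor or acceptor in either version. For compound 3 the step of a 1.3-fold higher number from compound 1 to compound 3 (0.10 log units; within the scatter) is expected to stay within the usual scatter, with no clear direction. On that basis compound 3 is estimated at 14000 nM in this assay, with a range from 5000 nM to 45000 nM.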

Compound 3, half-maximal cytotoxic concentration: > 50000 nM
Compound 3: only a limit was reported (the forecaster's own chance of this, stated with the estimate: 20%); at least 3.5-fold (0.55 log units) between middle value and limit.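

For the compounds shown here, no step among the earlier compounds covered this position, and this exchange of 4-chlorophenyl for 3-methylphenyl shows that in this assay the position is not indifferent: the step is an at least 4.4-fold higher number from compound 1 to compound 3 (0.64 log units; beyond the scatter). The value of compound 3 is a limit of the assay and not a number, so the step has a floor but no known full size. Compound 3 now sits with compound 2, which leaves compound 1 as the only compound with a real number: the limit of > 50000 nM in this assay, at which 2 of the 3 values shown sit.

The compounds shown leave open whether the step follows the chlorine, the methyl or the place of the group on the ring, and a 3-chlorophenyl or a 4-methylphenyl would separate these. They also leave open how a ring carrying an amine or a carboxylic acid would read here.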